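Cyclohexyl for Hexyl on the Amide Nitrogen

The source may report more compounds than this note shows. Statements on the series, on what has been measured and on what is new or still open speak of the compounds shown alone.

Among the compounds with values here, compound 2 `CCCCCCNC(=O)COc1ccc(-c2cc(C(=O)O)c3ccccc3n2)cc1OC` is one of two compounds measured in an ADME assay on HaCaT cells (Homo sapiens) for inhibition; on this read-out lower numbers stand for stronger inhibition and higher numbers for weaker inhibition. For compound 2 the assay reports only a limit, > 300000 nM, and not a number. Compound 1 `COc1cc(-c2cc(C(=O)O)c3ccccc3n2)ccc1OCC(=O)Nc1ccc(C(F)(F)F)cc1` gives 150000 nM. Within the data shown here, the one recorded step, an at least 2.0-fold higher number from compound 1 to compound 2 (0.30 log units; that floor lies within the scatter), puts hexyl in place of 4-(trifluoromethyl)phenyl on an amide-type nitrogen, and it ends at the limit described by the limit of > 300000 nM in this assay, at which 1 of the 2 values shown sits. Compound 3 `COc1cc(-c2cc(C(=O)O)c3ccccc3n2)ccc1OCC(=O)NC1CCCCC1` is not yet measured; it differs from compound 2 by cyclohexyl in place of hexyl on an amide-type nitrogen. Among the measured compounds shown here, no measured step swaps a chain for a ring of the same size. For the measured compounds named here, the only guide is that compound 2 already stands at the limit > 300000 nM. Compound 3 is therefore expected to move little, with a step of about a number no higher from compound 2 to compound 3 (the limit leaves the size open), not beyond the scatter. The estimate for compound 3 in this assay is 300000 nM, within a range from 100000 nM to 700000 nM, and it is expected that the assay may again return only a limit.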

Compound 3, half-maximal inhibitory concentration in the HaCaT assay: > 300000 nM
Compound 3: only a limit was reported (the forecaster's own chance of this, stated with the estimate: 60%); the middle value sits exactly at the limit.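

In the HaCaT assay compound 3 gives > 300000 nM, which is a limit of the assay and not a number. A ring on the amide-type nitrogen now ends in the same place as an open chain: the limit of > 300000 nM in the HaCaT assay, at which 2 of the 3 values shown sit.

Compared with the 4-(trifluoromethyl)phenyl group of compound 1, cyclohexyl gives an at least 2.0-fold higher number from compound 1 to compound 3 (0.30 log units; that floor lies within the scatter), so a second replacement at this position also reaches the limit, with a floor that does not go beyond the scatter. Within the data shown here, no step between the two limits can be read in the HaCaT assay. In a physicochemical assay for lipophilicity, using the shake flask method, in phosphate buffer, measured as octanol-water partition, at pH 7.4 (a higher number here means a more lipophilic compound, a lower number a more polar compound), compound 2 gives 1 and compound 3 gives 0.8, and the same change gives a number 0.20 log units lower from compound 2 to compound 3 (within the scatter), which does not separate the ring from the chain.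

From the compounds shown here alone, how compound 2 and compound 3 truly compare in the HaCaT assay stays open. So does whether a plain phenyl or a chain ending in an amine on this nitrogen would give a measurable number.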